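The source may hold more compounds than are shown below. What is called first, only, known or untested is meant among the compounds shown, and "the series" means these compounds.

Compound 1 `Cc1cccc(-c2cc3occ(C)c3c(=O)o2)c1`: 43.8 uM
Compound 2 `COc1cc(OC)cc(-c2cc3occ(C)c3c(=O)o2)c1`: > 69.9 uM

Both compounds were read in a functional assay on KB cells (Homo sapiens) for cytotoxicity, read by sulforhodamine B assay, with a stated time of 72 h; a higher number here means that more compound is needed for the effect, a lower number that less compound is needed. Compound 2 gives only a limit of the assay, > 69.9 uM, and no number. The position on the data so far is the limit of > 69.9 uM in this assay, at which 1 of the 2 values shown sits.

Compound 3 `COc1cc(-c2cc3occ(C)c3c(=O)o2)cc(OC)c1OC` follows from compound 2 with methoxy in place of hydrogen on an aromatic carbon, ortho to two methoxy groups and para to a large group: methoxy in place of hydrogen on an aromatic carbon. Going by the values given here, no measured step between compounds differing in one place is available to size this change. Among the compounds with values here, the only numerical guide is compound 1 at 43.8 uM. The expected at least 1.3-fold lower number from compound 2 to compound 3 (0.14 log units; that floor lies within the scatter) is small, towards less compound needed, and may not go beyond the scatter. In this assay the estimate for compound 3 is 50 uM, with an expected range of 20 uM to 90 uM.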

Compound 3, concentration for half-maximal effect: > 63.3 uM
Compound 3: a limit, no number (the forecaster's own chance of this, stated with the estimate: 55%); middle value at least 1.2-fold (0.10 log units) from the limit.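

Compound 3 gives only a limit, > 63.3 uM, as compound 2 does, so no step can be read between compound 2 and compound 3. Going by these compounds, whether methoxy in place of hydrogen on an aromatic carbon changes the concentration needed at all stays open.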